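The source may report more compounds than this note shows. Statements on the series, on what has been measured and on what is new or still open speak of the compounds shown alone.

The measured compounds:

Compound 1, `CCCC(=O)N1CC2CC(C1)N2`, in an assay on SH-EP1 cells for agonist activity at Neuronal acetylcholine receptor; alpha4/beta2 (Homo sapiens), read by FLIPR and calcium flux (a higher number here means that more compound is needed for the effect, a lower number that less compound is needed), compound 1 gives 850 nM.
Compound 2, `C[C@@H]1C[C@@H]1C(=O)N1CC2CC(C1)N2`, gives 3800 nM.
Compound 3, `C[C@@H]1C[C@H]1C(=O)N1CC2CC(C1)N2`, gives 2900 nM.

Compound 1 stands with the lowest number of the three. Its nearest neighbour is compound 3, reached by a 3.4-fold higher number from compound 1 to compound 3 (0.53 log units; beyond the scatter), and its furthest is compound 2, reached by a 4.5-fold higher number from compound 1 to compound 2 (0.65 log units; beyond the scatter). Between the two cyclopropyl compounds there is a 1.3-fold lower number from compound 2 to compound 3 (0.12 log units; within the scatter), a difference that may be tied to the fact that one of compounds 2 and 3 is drawn with a defined configuration and the other without, at the place where they differ.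

Compound 4, `C[C@H]1C[C@@H]1C(=O)N1CC2CC(C1)N2`, has not yet been measured. It differs from compound 1 by 2-methylcyclopropyl in place of propyl on a carbonyl carbon. The two measured steps from compound 1 to compound 2 and from compound 1 to compound 3 bear directly on it, as each of them puts a 2-methylcyclopropyl in place of the same propyl on the carbonyl carbon, and compound 4 differs from those two only in the configuration of its stereocentres. Both steps were modest rises beyond the scatter, and the two cyclopropyl compounds lie within the scatter of each other. Compound 4 is therefore expected to show a modest rise of about a 3.8-fold higher number from compound 1 to compound 4 (0.58 log units; beyond the scatter). Compound 4 is estimated at 3200 nM, with a range from 1400 nM to 7500 nM.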

Compound 4, half-maximal effective concentration: 14000 nM
The estimate for compound 4 lay 4.4-fold (0.64 log units) below the measured number; measured number outside the range, above it.
By their numbers in this assay, from the lowest: compound 1; then compounds 3 and 2 (each within the scatter of the next); then compound 4.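

In this assay, compound 4 shows that replacing propyl with 2-methylcyclopropyl on this carbonyl carbon has no single outcome: with the same atoms and bonds as the two earlier cyclopropyl compounds, which lay within the scatter of each other, it gives a large step, a 16-fold higher number from compound 1 to compound 4 (1.22 log units; beyond the scatter). With a 3.7-fold higher number from compound 2 to compound 4 (0.57 log units; beyond the scatter), a single stereocentre at a saturated ring carbon differs, so configuration now separates compounds beyond the scatter, and this step may be tied to: the fact that one of compounds 2 and 4 is drawn with a defined configuration and the other without, at the place where they differ With a 4.8-fold higher number from compound 3 to compound 4 (0.68 log units; beyond the scatter), two such stereocentres differ, and this step may be tied to: the fact that one of compounds 3 and 4 is drawn with a defined configuration and the other without, at the place where they differ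

The compounds shown leave open whether an unsubstituted cyclopropyl, or a longer chain such as butyl, on the same carbonyl carbon would stay close to compound 1 or rise as the 2-methylcyclopropyl compounds do. They also leave open why a change of configuration made no difference beyond the scatter in one pair but did in the two pairs that include compound 4, and whether the same order would hold on a different core.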